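A Trichlorophenyl Limit and Its Methoxyphenyl Counterpart

The source may report more compounds than this note shows. Statements on the series, on what has been measured and on what is new or still open speak of the compounds shown alone.

Of the compounds shown here, three have been measured in a functional assay on A549 cells (Homo sapiens) for antiproliferative activity, read by MTT assay, with a stated time of 72 h (a lower number here means a stronger inhibitor, a higher number a weaker inhibitor), and their readings lie far apart. Compound 1 `CC(C)(C)c1ccc(OCCCON2C(N)=NC(N)=NC23CCSCC3)cc1` gives 1 nM. Compound 3 `NC1=NC2(CCOCC2)N(OCCCOc2cccc(Br)c2)C(N)=N1`, which carries a different core, gives 160 nM. Compound 2 `NC1=NC2(CCSCC2)N(OCCCOc2cc(Cl)c(Cl)cc2Cl)C(N)=N1` is reported as > 100000 nM, and this reading is a limit of the assay, not a number. Among the compounds with values here, it is the only one of the three readings that is a limit, so the true potency of compound 2 remains unknown.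

Compound 4 `COc1ccc(OCCCON2C(N)=NC(N)=NC23CCSCC3)cc1` keeps the core of compound 2 and changes one group: 4-methoxyphenyl in place of 2,4,5-trichlorophenyl on an oxygen on a saturated carbon. In words, 4-methoxyphenyl stands in place of 2,4,5-trichlorophenyl on an oxygen on a saturated carbon. Within the data shown here, no measured pair isolates this exchange, so any forecast is loose. A shift well beyond the scatter toward lower numbers in this assay is still expected, because compound 1 on the same core gives 1 nM. That value shows only what this core can reach with another group in this place, so a result as low is not assumed. The expected change is an at least 1000-fold lower number from compound 2 to compound 4 (3.00 log units; beyond the scatter). For compound 4 the estimate is 100 nM, with an expected range of 5 nM to 3000 nM.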

Compound 4, half-maximal inhibitory concentration: 240 nM
The estimate for compound 4 lay 2.4-fold (0.38 log units) below the measured number; measured number inside the range.
By their numbers in this assay, from the lowest: compound 1; then compounds 3 and 4 (each within the scatter of the next). At a limit, above all of these: compound 2.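

On the shared core, 4-methoxyphenyl in place of 2,4,5-trichlorophenyl on an oxygen on a saturated carbon gives an at least 410-fold lower number from compound 2 to compound 4 (2.61 log units; beyond the scatter) in this assay, so an exchange at this place alone can move the reading well beyond the scatter. Going by these compounds, the reading for compound 2 is a limit of the assay and not a number, so the full size of this step stays unknown: the limit of > 100000 nM in this assay, at which 1 of the 4 values shown sits A second exchange, methoxy in place of tert-butyl on an aromatic carbon, gives a 240-fold higher number from compound 1 to compound 4 (2.38 log units; beyond the scatter), which shows that on this core the reading also depends strongly on which of these two groups the aromatic ring carries, and not only on the loss of 2,4,5-trichlorophenyl.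

The compounds shown leave open whether a single chlorine, a fluorine or a hydroxyl on the aromatic ring would give a reading nearer that of compound 1 or that of compound 4. They also leave open how far each of the three chlorines contributes to the limit, and how the core of compound 3 would respond to a tert-butyl or a methoxy group on its aromatic ring.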